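This account rests on a few compounds, and the source may have more. Where it says the series, first, only, none or still open, it means among the compounds named here.

Measured so far:
- compound 1, `CC(c1ccccc1)N1CCN(c2c(Cl)cnc3[nH]c(-c4ccc(N(C)C)cc4)nc23)CC1`, 900 nM
- compound 2, `CN(C)c1ccc(-c2nc3c(N4CCN(Cc5ccncc5)CC4)c(Br)cnc3[nH]2)cc1`, 700 nM
- compound 3, `CN(C)Cc1ccc(-c2nc3c(N4CCN(CC(=O)Nc5nccs5)CC4)c(Br)cnc3[nH]2)cc1`, 1000 nM

All three values come from a functional assay on HCT-116 cells (Homo sapiens) for inhibition, read by MTT assay, with a stated time of 72 h; on this read-out higher numbers stand for weaker inhibition of growth and lower numbers for stronger inhibition of growth. Compound 2 sits at the low end of the three numbers, yet its gaps to compound 1 and to compound 3 both fall within the scatter, so the three compounds are not separated on this read-out. Compound 4, `CN(C)c1ccc(-c2nc3c(N4CCN(CC(=O)Nc5cccnc5)CC4)c(Br)cnc3[nH]2)cc1`, is not yet measured. Relative to compound 2 the change is (pyridin-3-yl)carbamoyl in place of pyridin-4-yl on a saturated chain carbon bound to an amine nitrogen in a ring. Going by the values given here, no step between measured compounds isolates this change; compound 3, which carries a carbamoyl group on the same saturated chain carbon, gives 1000 nM in this assay, in the same range as the others. The step expected is a 1.2-fold higher number from compound 2 to compound 4 (0.08 log units; within the scatter), none beyond the scatter. Compound 4 is estimated at 850 nM, range 350 nM to 2000 nM.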

Compound 4, concentration for 50% growth inhibition: 1650 nM
Compound 4: middle estimate off by 1.9-fold (0.29 log units), on the low side; the range from low to high includes it.
By their numbers in this assay, from the lowest: compounds 2, 1, 3 and 4 (each within the scatter of the next, the first and the last beyond it).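

In this assay, going by these compounds alone, (pyridin-3-yl)carbamoyl in place of pyridin-4-yl on a saturated chain carbon bound to an amine nitrogen in a ring gives a 2.4-fold higher number from compound 2 to compound 4 (0.37 log units; beyond the scatter), the only step so far that can be read. This position therefore responds to the change, modestly, and in the direction of weaker inhibition of growth. No measured evidence bears on the cause of this step.

As far as these compounds go, the step alters the carbamoyl link and the pyridine attachment together, so the share of each stays open. A (pyridin-4-yl)carbamoyl group at this carbon would separate the two.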